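Methoxycarbonyl for tert-butyl on the benzyl arm

The source may hold more compounds than are shown below. What is called first, only, known or untested is meant among the compounds shown, and "the series" means these compounds.

Compound 1 `CN1CCC[C@@H]1Cn1nc(Cc2ccc(C(C)(C)C)cc2)c2ccccc2c1=O` is the small member of the series. In an assay for binding affinity to Alpha-1A adrenergic receptor (Homo sapiens) (on this read-out lower numbers stand for stronger inhibition and higher numbers for weaker inhibition), compound 1 gives only a limit of > 1990 nM, so no number is known for it. Compound 2 `O=c1c2ccccc2c(Cc2ccc(Cl)cc2)nn1C[C@H]1CCCN1CCCCCc1ccc(OCCCN2CCCCCC2)cc1` carries a long extension on the shared core; in this assay compound 2 gives 25.1 nM. Within the data shown here, the two values show compound 2 well inside the range where numbers are reported and compound 1 outside it; no single-point step links the pair, so nothing further is drawn from them. What is known of compound 1 is the limit of > 1990 nM in this assay, at which 1 of the 2 values shown sits, alone.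

Compound 3 `COC(=O)c1ccc(Cc2nn(C[C@H]3CCCN3C)c(=O)c3ccccc23)cc1` differs from compound 1 by one change: methoxycarbonyl in place of tert-butyl on an aromatic carbon. Among the measured compounds shown here, no measured step of this kind exists. The expectation is that compound 3 stays close to where compound 1 stands, with a step that the limit leaves unreadable from compound 1 to compound 3 expected to be no larger than the scatter. Compound 3 is estimated at 3000 nM in this assay, with a range from 800 nM to 15000 nM, and a limit rather than a number is the more likely outcome.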

Compound 3, inhibition constant: > 1990 nM
Compound 3 ended at the assay's limit (the forecaster's own chance of this, stated with the estimate: 60%); the middle value lies beyond the limit too.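

Compound 1 and compound 3 both end at a limit of this assay rather than at a number, so no step between them can be read: the limit of > 1990 nM in this assay, at which 2 of the 3 values shown sit.

The compounds shown leave open how far each lies past that limit, and whether methoxycarbonyl in place of tert-butyl changes the read-out at all.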